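The source may hold more compounds than are shown below. What is called first, only, known or untested is meant among the compounds shown, and "the series" means these compounds.

Compound 2 `Cc1nc2c3ccccc3ccc2c2nc3c(ccc4ccccc43)c(-c3ccccc3N)c12` carries a 2-aminophenyl group on the shared core. In a functional assay on HeLa cells (Homo sapiens) for cytotoxicity, read by MTT assay, with a stated time of 48 h (a higher number here means a weaker inhibitor, a lower number a stronger inhibitor), compound 2 gives 16200 nM, the higher of the two numbers shown. Compound 1 `Cc1nc2c3ccccc3ccc2c2nc3c(ccc4ccccc43)c(-c3nccnc3N)c12`, which bears a 3-aminopyrazin-2-yl group, gives 1210 nM, and the step of a 13-fold higher number from compound 1 to compound 2 (1.13 log units; beyond the scatter) lies beyond the scatter. Compound 3 `Cc1nc2c3ccccc3ccc2c2nc3c(ccc4ccccc43)c(-c3ccccc3Cl)c12` carries a 2-chlorophenyl group, and in this assay compound 3 reaches only the limit > 80000 nM. Compound 4 `Cc1nc2c3ccccc3ccc2c2nc3c(ccc4ccccc43)c(-c3ccccc3)c12` has not yet been measured; it differs from compound 2 by hydrogen in place of amino on an aromatic carbon. The step of an at least 4.9-fold higher number from compound 2 to compound 3 (0.69 log units; beyond the scatter) is the closest guide, and a weakening step in the same direction, a 2.5-fold higher number from compound 2 to compound 4 (0.39 log units; beyond the scatter), is expected. Compound 4 is therefore estimated at 40000 nM, with a range from 15000 nM to 120000 nM.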

Compound 4, half-maximal inhibitory concentration: > 80000 nM
Compound 4: only a limit was reported; the forecaster's own chance of this, stated with the estimate: 35%; middle value at least 2.0-fold (0.30 log units) away from the limit.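

In this assay, hydrogen in place of amino gives an at least 4.9-fold higher number from compound 2 to compound 4 (0.69 log units; beyond the scatter), so the weakening seen with chloro appears with plain hydrogen too, and of the three groups tried on the phenyl ring only amino keeps a readable value. Phenyl in place of 3-aminopyrazin-2-yl gives an at least 66-fold higher number from compound 1 to compound 4 (1.82 log units; beyond the scatter). Compound 3 and compound 4 cannot be ordered against each other because each stands only at a limit: the limit of > 80000 nM in this assay, at which 2 of the 4 values shown sit.

From the compounds shown here alone, whether a hydroxyl, methoxy or methylamino group could stand in for amino remains open. So does the effect of a pyrazin-2-yl group without its amino group.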